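A small ring added to a slowly cleared compound

The source may report more compounds than this note shows. Statements on the series, on what has been measured and on what is new or still open speak of the compounds shown alone.

Measured so far in an in vitro ADME assay on microsomes from Gut (Homo sapiens) for metabolic stability, in the presence of a further agent that is not named here; a higher number here means faster removal of the compound, a lower number slower removal:
Compound 1 (`COc1ccc(C)cc1Cn1c(C(=O)NCC(C)(C)CO)cc2cc(C#N)ccc21`) gives 64 mL.min-1.g-1
Compound 2 (`CC(O)CCNC(=O)c1cc2cc(C#N)ccc2n1Cc1cccc(OC(F)(F)F)c1`) gives < 6 mL.min-1.g-1

Compound 2 stands at the low end of these two results, but its < 6 mL.min-1.g-1 is a limit of the assay and not a number. Compound 3 (`N#Cc1ccc2c(c1)cc(C(=O)NCCC1(O)CCC1)n2Cc1cccc(OC(F)(F)F)c1`) differs from compound 2 in one place (1-hydroxycyclobutyl in place of 1-hydroxyethyl on a saturated chain carbon, two bonds along the chain from an amide-type nitrogen), with 1-hydroxycyclobutyl in place of 1-hydroxyethyl on a saturated chain carbon, two bonds along the chain from an amide-type nitrogen. In this assay, going by the values given here, no measured pair shows what such a change does. The expectation therefore rests on compound 2 alone, with its < 6 mL.min-1.g-1 as the starting limit. A small upward step, within the usual scatter, is expected (an at least 1.3-fold higher number from compound 2 to compound 3 (0.12 log units; that floor lies within the scatter)), so clearance should stay low. Compound 3 is expected at 8 mL.min-1.g-1 (estimated range 4 mL.min-1.g-1 to 20 mL.min-1.g-1).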

Compound 3, intrinsic clearance in microsomes: < 6 mL.min-1.g-1
Compound 3: a limit, no number; the forecaster's own chance of this, stated with the estimate: 40%; at least 1.3-fold (0.12 log units) between middle value and limit.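

In this assay, going by these compounds alone, compound 2 and compound 3 each give a limit and not a number, so no step between them can be read: the limit of < 6 mL.min-1.g-1 in this assay, at which 2 of the 3 values shown sit. The compounds shown leave open whether 1-hydroxycyclobutyl in place of 1-hydroxyethyl changes clearance at all, and in which direction.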